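The source may hold more compounds than are shown below. What is called first, only, known or untested is meant among the compounds shown, and "the series" means these compounds.

Compound 1 `O=C(NCCCCc1ccccc1)c1cccc(C2SCC(=O)N2c2cnccn2)c1` is a thiazolidinone-type core that carries a pyrazin-2-yl group on its ring nitrogen. In a functional assay on HOS-TE85 cells (Homo sapiens) for inhibition, read by CCK-8 assay, with a stated time of 72 h (a higher number here means a weaker inhibitor, a lower number a stronger inhibitor), compound 1 gives only a limit, > 1000 nM, not a number. Compound 2 `COc1ccccc1N1C(=O)CSC1c1cccc(C(=O)NCCCCn2cncn2)c1` likewise gives only a limit in this assay, > 1000 nM. Compound 3 `C#Cc1cc(C(=O)NCCCCc2ccccc2)cc(C2SCC(=O)N2c2ccccc2OC)c1`, by contrast, gives 40.8 nM in this assay. Compound 1 thus sits at the limit of > 1000 nM in this assay, at which 2 of the 3 values shown sit. Compound 4 `O=C(NCCCCc1ccccc1)c1cccc(C2SCC(=O)N2c2ccccc2F)c1` differs from compound 1 in one place: 2-fluorophenyl in place of pyrazin-2-yl on an amide-type nitrogen in a ring. Among the compounds with values here, no measured pair shows this same change, so the size of the step is open. Compound 4 is expected to become a somewhat stronger inhibitor, with the step of an at least 1.6-fold lower number from compound 1 to compound 4 (0.22 log units; that floor lies within the scatter), and its estimated value in this assay is 600 nM, between 100 nM and 3000 nM.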

Compound 4, half-maximal inhibitory concentration: 34.1 nM
Compound 4: middle estimate off by 18-fold (1.25 log units), on the high side, and the stated range ends above it.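

Within the data shown here, the group on the amide-type nitrogen of the shared core proves decisive: 2-fluorophenyl in place of pyrazin-2-yl gives an at least 29-fold lower number from compound 1 to compound 4 (1.46 log units; beyond the scatter) in this assay and is the first step that isolates this position. The true step may be larger, since compound 1 gives only a limit: the limit of > 1000 nM in this assay, at which 2 of the 4 values shown sit. Going by these compounds, whether the gain comes from the fluorine or from the all-carbon ring stays open. A plain phenyl ring or a 2-chlorophenyl group at this position would help to separate the two.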